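Aminophenyl amide series: moving the ring amino group

The source may hold more compounds than are shown below. What is called first, only, known or untested is meant among the compounds shown, and "the series" means these compounds.

Measured so far:
compound 1, `Nc1ccc(Nc2c(C(=O)NCc3ccc(F)cc3)nc(Br)c3cccnc23)cc1`, 7000 nM
compound 2, `N[C@H]1CC[C@H](Nc2c(C(=O)NCc3ccccn3)nc(Br)c3cccnc23)CC1`, 4000 nM
compound 3, `N[C@H]1CC[C@H](Nc2c(C(=O)NCc3cccc(C(F)(F)F)c3)nc(Br)c3cccnc23)CC1`, 4200 nM

In a functional assay on MDA-MB-435 cells (Homo sapiens) for cytotoxicity, read by MTT assay, with a stated time of 72 h (a lower number here means a stronger inhibitor, a higher number a weaker inhibitor), compound 1 gives 7000 nM, the highest of the three numbers; compound 3 gives 4200 nM and compound 2 gives 4000 nM, and both lie within the scatter of compound 1, so no order among the three can be read.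

Compound 4, `Nc1cccc(Nc2c(C(=O)NCc3ccc(F)cc3)nc(Br)c3cccnc23)c1`, has not been measured. It differs from compound 1 by 3-aminophenyl in place of 4-aminophenyl on a nitrogen on an aromatic ring. Going by the values given here, the only measured step, a 1.1-fold higher number from compound 2 to compound 3 (0.02 log units; within the scatter), changes the group on the saturated chain carbon bound to the amide-type nitrogen and leaves the part altered here untouched, so it gives no guide to this change. Among the compounds with values here, no other pair speaks to it. With nothing pointing either way, the step of no change at the digits printed from compound 1 to compound 4 (within the scatter) is therefore expected to stay within the scatter. Compound 4 is estimated at 7000 nM in this assay, with a range from 3000 nM to 16000 nM.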

Compound 4, half-maximal inhibitory concentration: 8000 nM
Compound 4: middle estimate off by 1.1-fold (0.06 log units), on the low side; low and high end bracket the measured number.
By their numbers in this assay, from the lowest: compounds 2, 3, 1 and 4 (each within the scatter of the next).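

Moving the ring amino group gives a 1.1-fold higher number from compound 1 to compound 4 (0.06 log units; within the scatter) in this assay, so 3-aminophenyl and 4-aminophenyl on this nitrogen cannot be told apart in this assay. Going by these compounds alone, this is the first measured step at this position, as the earlier step changed only the group on the saturated chain carbon bound to the amide-type nitrogen. Nothing available here offers a reason for the result.

As far as these compounds go, whether the amino group contributes at all remains open, and a hydroxyl group or a carboxylic acid in its place on the phenyl ring, or a longer aminomethyl chain, would bear on that. Compound 1 and compound 4 also differ from compound 2 and compound 3 in more than one place, so the effect of the aminophenyl group against the saturated ring cannot be separated from that of the amide substituent.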